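From octylsulfanyl to isobutylamino, close to the assay limit

The compounds below may be only part of what the source reports. "The series", "measured", "known", "first", "only" and "open" are said of these compounds alone.

In an ADME assay on HFF cells (Homo sapiens) for cytotoxicity, with a stated time of 8 days (a lower number here means that less compound is tolerated, a higher number that more compound is tolerated), compound 1 `CNc1nc(N)nc2c1ncn2/C=C1/CC1(CO)CO` gives 265000 nM. Compound 2 `Nc1nc(NCc2ccccc2)c2ncn(/C=C3/CC3(CO)CO)c2n1` gives > 300000 nM, which is a limit. Compound 3 `CCCCCCCCSc1nc(N)nc2c1ncn2/C=C1/CC1(CO)CO` gives > 300000 nM, which is also a limit. Going by the values given here, the numbers so far are thus marked by the limit of > 300000 nM in this assay, at which 2 of the 3 values shown sit. Compound 4 `CC(C)CNc1nc(N)nc2c1ncn2/C=C1/CC1(CO)CO` has isobutylamino in place of octylsulfanyl on an aromatic carbon. Changes within this substituent gave an at least 1.1-fold higher number from compound 1 to compound 2 (0.05 log units; that floor lies within the scatter) and an at least 1.1-fold higher number from compound 1 to compound 3 (0.05 log units; that floor lies within the scatter), and also a step that the two limits leave unreadable from compound 2 to compound 3. No step beyond the scatter is therefore expected in this assay. The expected step is an at least 1.0-fold lower number from compound 3 to compound 4 (0.02 log units; that floor lies within the scatter). Compound 4 is estimated at 280000 nM, with an expected range of 170000 nM to 400000 nM.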

Compound 4, half-maximal cytotoxic concentration: > 300000 nM
Compound 4 was reported as a limit; the forecaster's own chance of this, stated with the estimate: 55%; middle value at least 1.0-fold (0.02 log units) away from the limit.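

In this assay, the value of compound 4 is a limit, so its steps to compound 2 and compound 3 cannot be read. Going by these compounds alone, the one readable step is an at least 1.1-fold higher number from compound 1 to compound 4 (0.05 log units; that floor lies within the scatter). Isobutylamino thus becomes the third group on this aromatic carbon to reach the limit, after benzylamino and octylsulfanyl: the limit of > 300000 nM in this assay, at which 3 of the 4 values shown sit.

Any order among compound 2, compound 3 and compound 4 stays open. So does whether a carboxylic acid or a piperazine on this aromatic carbon would give a clearly lower number.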